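Triazolopyrimidine amines: corticotropin-releasing factor receptor 1 binding notes

The source may report more compounds than this note shows. Statements on the series, on what has been measured and on what is new or still open speak of the compounds shown alone.

Measured so far:
compound 1, `CCCCN(CC)c1nc(C)nc2c1nnn2-c1c(C)cc(C)nc1C`, 65 nM
compound 2, `CCCC(C)Nc1nc(C)nc2c1nnn2-c1c(C)cc(C)cc1C`, 7.1 nM
compound 3, `COCC(COC)Nc1nc(C)nc2c1nnn2-c1ccc(C(C)C)cc1Br`, 10.3 nM

In an in vitro assay on 293-EBNA cells for binding affinity to corticotropin-releasing factor receptor 1 (Homo sapiens) (a higher number here means a weaker inhibitor, a lower number a stronger inhibitor), compound 3 gives 10.3 nM, the second highest of the three numbers. Its nearest neighbour is compound 2 at 7.1 nM, a gap within the scatter; the furthest is compound 1 at 65 nM, a gap beyond the scatter.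

The next compound is compound 4, `CCC(CO)Nc1nc(C)nc2c1nnn2-c1ccc(C(C)C)cc1Br`. It differs from compound 3 by 1-(hydroxymethyl)propyl in place of 2-methoxy-1-(methoxymethyl)ethyl on a nitrogen on an aromatic ring, the change sitting on the nitrogen of the shared core. For the measured compounds named here, no measured pair isolates this change, so its effect is unknown. With both ends of the change being small, acyclic, and carrying oxygen, the step of a 1.2-fold higher number from compound 3 to compound 4 (0.07 log units; within the scatter) is expected to be small and not clearly beyond the scatter. Compound 4 is estimated at 12 nM, with a range from 4 nM to 40 nM.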

Compound 4, inhibition constant: 25.3 nM
For compound 4 the middle estimate is 2.1-fold (0.32 log units) below the measured one, and the stated range covers the measured number.
By their numbers in this assay, from the lowest: compounds 2 and 3 (each within the scatter of the next); then compound 4; then compound 1.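

For the compounds shown here, this is the first pair that differs only on the nitrogen of the shared core. In this assay, 1-(hydroxymethyl)propyl in place of 2-methoxy-1-(methoxymethyl)ethyl gives a 2.5-fold higher number from compound 3 to compound 4 (0.39 log units; beyond the scatter) and so shows that the number responds at this place, even between two acyclic, oxygen-bearing groups. Chain size and donor count change together here, and nothing at hand explains the step.

Open, on these data alone, is whether the hydroxyl itself matters, which 1-(methoxymethyl)propyl on the same nitrogen would test. Also open, as far as these compounds go, is how an amine or a carboxylic acid at the chain end would read.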